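The source may hold more compounds than are shown below. What is called first, only, known or untested is meant among the compounds shown, and "the series" means these compounds.

Measured so far in an ADME assay on microsomes from liver (Mus musculus) for metabolic stability, read by LC-MS, using NADPH, with a stated time of 30 min, tested at 0.1 uM; on this read-out higher numbers stand for a more stable compound and lower numbers for a less stable compound:
- compound 1 `O=S(=O)(NCC1COC1)c1cccc(-c2ccc3nccc(-c4ccncc4)c3n2)c1` gives 19% of the compound remaining
- compound 2 `NS(=O)(=O)c1cncc(-c2ccc3nccc(-c4cn[nH]c4)c3n2)c1` gives 2% of the compound remaining

Compound 1 holds the higher of these two numbers, and its gap to compound 2 lies beyond the usual scatter of repeated measurements. Even so, most of compound 1 is gone by the end of the test.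

The next compound to consider is compound 3 `CS(=O)(=O)Nc1cccc(-c2ccc3nccc(-c4ccncc4)c3n2)c1`. It carries methanesulfonamido in place of ((oxetan-3-yl)methyl)sulfamoyl on an aromatic carbon of a six-membered aromatic ring of carbon only, and this group sits meta to a large group (methanesulfonamido in place of ((oxetan-3-yl)methyl)sulfamoyl on an aromatic carbon).

Among the measured compounds shown here, no two measured compounds differ in one place only, so nothing here shows directly what such a swap does. The expected change, a number 1 percentage points higher from compound 1 to compound 3 (within the scatter), is estimated to stay within the scatter of this assay, with no clear direction. For compound 3 the expected value is 20%, with an estimated range from 5% to 45% as the likely outcome.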

Compound 3, percent of the compound remaining: 50%
The estimate for compound 3 lay 30 percentage points below the measured number; the whole stated range lies below it.
By their numbers in this assay, from the lowest: compound 2; then compound 1; then compound 3.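

In this assay, the change at this aromatic carbon gives a number 31 percentage points higher from compound 1 to compound 3 (beyond the scatter), so the group held here clearly matters for how much compound survives, which compounds 1 and 2 could not show because they differ in several places. The swap changes several things at once: the group shrinks, the four-membered ring is lost, and the sulfonyl no longer sits directly on the ring, with nitrogen attached there instead. Nothing at hand explains the rise or shows which of these changes drives it.

On these data alone, it remains open whether the rise depends on the ring loss, the smaller size or the reversed linkage, and a methylsulfamoyl group on the same carbon would help separate these. As far as these compounds go, it is also open whether a longer chain such as ethanesulfonamido would keep the gain.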